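The source may report more compounds than this note shows. Statements on the series, on what has been measured and on what is new or still open speak of the compounds shown alone.

In a functional assay on A549 cells (Homo sapiens) for inhibition, read by MTT assay, with a stated time of 72 h (a higher number here means a weaker inhibitor, a lower number a stronger inhibitor), compound 1 (`Nc1ncnc2c1c(-c1cnc3[nH]ccc3c1)nn2CC(=O)NO`), which has the shorter chain, gives only a limit of the assay, > 150000 nM. Among the compounds with values here, compound 2 (`Nc1ncnc2c1c(-c1cnc3[nH]ccc3c1)nn2CCCCCCCCC(=O)NO`) gives 12300 nM, the only actual number so far. Compound 3 (`Nc1ncnc2c1c(-c1cnc3[nH]ccc3c1)nn2CCCCCCC(=O)NO`) shortens the chain of compound 2: hydroxycarbamoyl in place of 2-(hydroxycarbamoyl)ethyl on a saturated chain carbon, six bonds along the chain from an aromatic nitrogen. Within the data shown here, no measured step isolates this change, so the expectation rests on compound 2 at 12300 nM. It also rests on compound 1, with the shorter chain, whose > 150000 nM is a limit of the assay. A modest weakening is expected, an estimated 2.0-fold higher number from compound 2 to compound 3 (0.31 log units; beyond the scatter). For compound 3 the expected value is 25000 nM, with an estimated range of 8000 nM to 80000 nM.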

Compound 3, half-maximal inhibitory concentration: 50000 nM
Compound 3: middle estimate off by 2.0-fold (0.30 log units), on the low side; measured number inside the range.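

In this assay, shortening the chain at this saturated chain carbon now has a measured size: a 4.1-fold higher number from compound 2 to compound 3 (0.61 log units; beyond the scatter). The chain of compound 3 also separates it from the shortest chain, with an at least 3.0-fold lower number from compound 1 to compound 3 (0.47 log units; beyond the scatter), so across these three compounds the number falls as the chain lengthens. Compound 1 gives only a limit of the assay: the limit of > 150000 nM in this assay, at which 1 of the 3 values shown sits.

On these data alone, whether a longer chain than that of compound 2 would lower the number further stays open. Also open, as far as these compounds go, is how an amine or a carboxylic acid in place of hydroxycarbamoyl would read.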